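Chloro position shift on the shared core of compound 1

A few compounds are considered here, and "the series" means these few. Any claim that something is new, unique, unknown or untested is made for them only; others in the source may bear on it.

Measured so far in a functional assay on SK-OV-3 cells (Homo sapiens) for cytotoxicity; on this read-out lower numbers stand for stronger inhibition and higher numbers for weaker inhibition:
compound 1, `O=C(CCCCCCc1nc2ccccc2[nH]1)NO`: 2700 nM
compound 2, `O=C(CCCCCCc1nc2ccc(Cl)cc2[nH]1)NO`: 320 nM
compound 3, `O=C(CCCCCCc1nc2ccc(-c3ccccc3F)cc2[nH]1)NO`: 7400 nM

Compound 1 stands second highest of the three numbers. Its nearest neighbour is compound 3, with a 2.7-fold higher number from compound 1 to compound 3 (0.44 log units; beyond the scatter); its furthest is compound 2, with an 8.4-fold lower number from compound 1 to compound 2 (0.93 log units; beyond the scatter). Compound 4, `O=C(CCCCCCc1nc2cccc(Cl)c2[nH]1)NO`, is not yet measured. It differs from compound 1 in one place: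
chloro in place of hydrogen on an aromatic carbon
The chloro in compound 4 sits ortho to a fused ring, not at the same aromatic carbon as the chloro of compound 2. For the measured compounds named here, the step from compound 1 to compound 2, a modest one, is the only direct precedent for chloro in place of hydrogen on this core; a 23-fold higher number from compound 2 to compound 3 (1.36 log units; beyond the scatter) adds that the same carbon tolerates chloro far better than 2-fluorophenyl. Going by the values given here, no measured compound carries chloro at the new place, so a gain is expected but smaller and less certain than in compound 2. Compound 4 is therefore expected to give 900 nM in this assay, within 300 nM to 3000 nM. That estimate corresponds to a 3.0-fold lower number from compound 1 to compound 4 (0.48 log units; beyond the scatter).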

Compound 4, half-maximal inhibitory concentration: 10000 nM
Estimate against measurement, compound 4: 11-fold (1.05 log units) below, and the stated range ends below it.
By their numbers in this assay, from the lowest: compound 2; then compound 1; then compounds 3 and 4 (each within the scatter of the next).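

In this assay chloro in place of hydrogen on the shared core does not act in one direction: on the aromatic carbon ortho to a fused ring, the step is a 3.7-fold higher number from compound 1 to compound 4 (0.57 log units; beyond the scatter), while compound 2, with chloro on a different aromatic carbon, stands at 320 nM on the other side of compound 1. The gain seen with compound 2 therefore does not carry over to this position, and on this core the outcome of the change depends on which aromatic carbon holds the chloro. Nothing at hand speaks to the reason for this difference between the two places.

The compounds shown leave open whether fluoro, methyl or methoxy on this same carbon would follow chloro here. They also leave open whether an amine or a carboxylic acid there, or a longer chain on the hydroxamic acid side, would alter the difference between the two places.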